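A few compounds are considered here, and "the series" means these few. Any claim that something is new, unique, unknown or untested is made for them only; others in the source may bear on it.

Three compounds have been measured in an ADME assay on MDA-MB-435 cells (Homo sapiens) for cytotoxicity (a lower number here means that less compound is tolerated, a higher number that more compound is tolerated), and each value is a limit of the assay, not a number:

- Compound 1 `COc1ccccc1-n1c(SCC(=O)NNC(=O)c2ccccc2O)nnc1-c1ccccc1O`: > 20000 nM
- Compound 2 `O=C(CSc1nnc(-c2ccccc2O)n1Cc1ccccc1)NNC(=O)c1ccccc1O`: > 20000 nM
- Compound 3 `O=C(CSc1nnc(Cc2ccccc2)n1-c1cccc(Cl)c1)NNC(=O)c1ccccc1O`: > 20000 nM

Compound 3 therefore has no exact position in the series, and neither do its two companions: the limit of > 20000 nM in this assay, at which 3 of the 3 values shown sit.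

The next compound, compound 4 `O=C(CSc1nnc(Cc2ccccc2)n1C1CCCCC1)NNC(=O)c1ccccc1O`, carries cyclohexyl in place of 3-chlorophenyl on an aromatic nitrogen. Among the measured compounds shown here, only one measured step touches that same kind of position, with benzyl in place of 2-methoxyphenyl on an aromatic nitrogen: a step that the two limits leave unreadable from compound 1 to compound 2. Both ends of that step are limits, so it gives no size to carry over. For the measured compounds named here, all three substituents tried on that nitrogen so far end at the limit, and this is the only guide available for this assay. The estimated change is a number no higher from compound 3 to compound 4 (the limit leaves the size open), and no shift beyond the scatter is expected in either direction. Compound 4 is expected at about 20000 nM, within an estimated range of 10000 nM to 40000 nM.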

Compound 4, half-maximal cytotoxic concentration: > 20000 nM
Compound 4: a limit, no number; the forecaster's own chance of this, stated with the estimate: 85%; the middle value sits exactly at the limit.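

Among the compounds shown here, compound 4, like compound 3, ends at a limit of the assay and not at a number, so no step between them can be read in this assay: the limit of > 20000 nM in this assay, at which 4 of the 4 values shown sit. The compounds shown leave open how far any of them stands from the others and whether any group on the aromatic nitrogen changes the read-out.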